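Swapping a Urea Morpholine for an Oxalamide Pyrrolidine

The source may report more compounds than this note shows. Statements on the series, on what has been measured and on what is new or still open speak of the compounds shown alone.

Three compounds sharing one core have been tested in a functional assay on MDA-MB-231 cells (Homo sapiens) for cytotoxicity, read by MTT assay, with a stated time of 72 h; a lower number here means a stronger inhibitor, a higher number a weaker inhibitor:

Compound 1, `COc1ccc(/C(=C(/CCNC(=O)NCc2ccccc2)c2ccccc2)c2ccccc2)cc1`, gives > 50000 nM, which is a limit of the assay and not a number.
Compound 2, `COc1ccc(/C(=C(/CCNC(=O)N2CCOCC2)c2ccccc2)c2ccccc2)cc1`, gives 42800 nM.
Compound 3, `COc1ccc(/C(=C(/CCNC(=O)C(=O)NC2CCCCC2)c2ccccc2)c2ccccc2)cc1`, gives 12200 nM.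

Of the two real numbers, compound 2 has the higher one, meaning it is the weaker of the pair. Its nearest neighbour is compound 3, and the step is clear: a 3.5-fold lower number from compound 2 to compound 3 (0.55 log units; beyond the scatter). Compound 4, `COc1ccc(/C(=C(/CCNC(=O)C(=O)N2CCCC2)c2ccccc2)c2ccccc2)cc1`, has not yet been measured. It differs from compound 2 in one place: (pyrrolidin-1-yl)carbonyl in place of morpholin-4-yl on a carbonyl carbon. Going by the values given here, two measured steps bear on this change. The step from compound 2 to compound 3 already involves a second carbonyl, with a cyclohexylcarbamoyl group taking the place of morpholin-4-yl, and it gave a modest gain. The step from compound 1 to compound 3 points the same way, though only as a floor: an at least 4.0-fold lower number from compound 1 to compound 3 (0.61 log units; beyond the scatter), since compound 1 sits at the limit of > 50000 nM in this assay, at which 1 of the 3 values shown sits. The step from compound 1 to compound 2 stayed within the scatter: an at least 1.1-fold lower number from compound 1 to compound 2 (0.06 log units; that floor lies within the scatter). Compound 4 gains the extra carbonyl but ends in a pyrrolidine ring rather than the cyclohexylamine of compound 3, so a gain of a similar or somewhat smaller size is expected: a 2.1-fold lower number from compound 2 to compound 4 (0.33 log units; beyond the scatter). Compound 4 is therefore estimated at 20000 nM, with a likely range from 8000 nM to 50000 nM.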

Compound 4, half-maximal inhibitory concentration: 48600 nM
Compound 4: the middle estimate sits 2.4-fold (0.39 log units) below what was measured; measured number inside the range.
By their numbers in this assay, from the lowest: compound 3; then compounds 2 and 4 (each within the scatter of the next). At a limit, above all of these: compound 1.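

In this assay, a second carbonyl combined with pyrrolidin-1-yl in place of morpholin-4-yl leaves no difference that can be told from the scatter, a 1.1-fold higher number from compound 2 to compound 4 (0.06 log units; within the scatter), so a second carbonyl does not bring a gain in every compound that carries it. With both carbonyls in place, the end group alone separates two compounds, and pyrrolidin-1-yl in place of cyclohexylamino gives a 4.0-fold higher number from compound 3 to compound 4 (0.60 log units; beyond the scatter), which ties the better value of compound 3 to its cyclohexylamino end and not to the second carbonyl alone. The remaining step, an at least 1.0-fold lower number from compound 1 to compound 4 (0.01 log units; that floor lies within the scatter), is only a floor and settles nothing, as one of its ends stands at a limit of the assay and not at a number: the limit of > 50000 nM in this assay, at which 1 of the 4 values shown sits.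

Still open, as far as these compounds go, is whether the better value belongs to cyclohexylamino in particular or to a wider set of end groups on the two carbonyls, which cyclopentylamino or an open-chain butylamino could help to separate. Also open, from the compounds shown here alone, is what cyclohexylamino gives on the single carbonyl of the urea, a pairing that would set the end group and the second carbonyl apart directly.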